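A bromo in place of nitro on the shared core

This account rests on a few compounds, and the source may have more. Where it says the series, first, only, none or still open, it means among the compounds named here.

In a functional assay on CCRF-CEM cells (Homo sapiens) for antiproliferative activity, read by fluorescence and resazurin assay, with a stated time of 48 h (on this read-out higher numbers stand for weaker inhibition and lower numbers for stronger inhibition), compound 1 `Cc1noc(NS(=O)(=O)c2ccc(NC(=O)c3cc4ccccc4oc3=O)cc2)c1C` gives 26600 nM, and compound 2 `Cc1noc(NS(=O)(=O)c2ccc(NC(=O)c3cc4cc([N+](=O)[O-])ccc4oc3=O)cc2)c1C` gives 14300 nM, so compound 2 stands within the scatter of compound 1. Compound 3 `Cc1noc(NS(=O)(=O)c2ccc(NC(=O)c3cc4cc(Br)ccc4oc3=O)cc2)c1C` follows from compound 2 through (bromo in place of nitro on an aromatic carbon), bromo in place of nitro on an aromatic carbon. For the measured compounds named here, the one measured step that bears on this, a 1.9-fold lower number from compound 1 to compound 2 (0.27 log units; within the scatter), put nitro in place of hydrogen on an aromatic carbon. Going by the values given here, with only that guide, no step beyond the scatter is expected in this assay. The estimated 1.0-fold higher number from compound 2 to compound 3 (0.02 log units; within the scatter) is expected to remain within that scatter. For compound 3 the expected value is 15000 nM, with an estimated range from 6000 nM to 35000 nM.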

Compound 3, half-maximal inhibitory concentration: 14600 nM
Compound 3: middle estimate off by 1.0-fold (0.01 log units), on the high side, and the stated range covers the measured number.
By their numbers in this assay, from the lowest: compounds 2, 3 and 1 (each within the scatter of the next).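

In this assay the change from nitro to bromo on this aromatic carbon gives a 1.0-fold higher number from compound 2 to compound 3 (0.01 log units; within the scatter), and the change from hydrogen to bromo gives a 1.8-fold lower number from compound 1 to compound 3 (0.26 log units; within the scatter). A group of one heavy atom with no hydrogen-bond acceptors and a group of three heavy atoms with two thus stand within the scatter of each other here, and no group at this place has yet produced a step beyond the scatter. Nothing at hand gives a cause for this result. As far as these compounds go, whether an amine or a carboxylic acid on this carbon would produce such a step stays open, as does the effect of changes elsewhere on the shared core.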